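This account rests on a few compounds, and the source may have more. Where it says the series, first, only, none or still open, it means among the compounds named here.

Compound 1 `OC[C@H]1O[C@@H](n2cnc3c(NCc4ccccc4Cl)ncnc32)[C@H](O)[C@@H]1O`: 1600 nM
Compound 2 `OC[C@H]1O[C@@H](n2cnc3c(NCc4ccc(Cl)c(Cl)c4)ncnc32)[C@H](O)[C@@H]1O`: 2000 nM

In a functional assay on HL-60 cells (Homo sapiens) for antiproliferative activity, with a stated time of 72 h (a higher number here means a weaker inhibitor, a lower number a stronger inhibitor), compound 1 and compound 2 stand within the scatter of each other: a 1.3-fold higher number from compound 1 to compound 2 (0.10 log units; within the scatter). Compound 3 `COc1ccc(CNc2ncnc3c2ncn3[C@@H]2O[C@H](CO)[C@@H](O)[C@H]2O)c(OC)c1` differs from compound 1 by 2,4-dimethoxyphenyl in place of 2-chlorophenyl on a saturated chain carbon bound to a nitrogen on an aromatic ring. For the measured compounds named here, the one measured step that bears on this, a 1.3-fold higher number from compound 1 to compound 2 (0.10 log units; within the scatter), also exchanges one substituted phenyl for another and stays within the scatter, but no measured compound carries methoxy groups, so the evidence is thin. A step of about a 1.6-fold higher number from compound 1 to compound 3 (0.19 log units; within the scatter) is expected, not beyond the scatter. Compound 3 is therefore estimated at 2500 nM, with a range from 800 nM to 8000 nM.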

Compound 3, half-maximal inhibitory concentration: 39000 nM
The estimate for compound 3 lay 16-fold (1.19 log units) below the measured number; measured number outside the range, above it.
By their numbers in this assay, from the lowest: compounds 1 and 2 (each within the scatter of the next); then compound 3.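

In this assay, this place on the saturated chain carbon does not treat every substituted phenyl alike: 2,4-dimethoxyphenyl gives a 24-fold higher number from compound 1 to compound 3 (1.39 log units; beyond the scatter) and a 20-fold higher number from compound 2 to compound 3 (1.29 log units; beyond the scatter). The two chlorine-bearing compounds had stayed within the scatter of each other, so they gave no sign that a change here could weaken the compound so strongly. No measurement on hand explains this loss. As far as these compounds go, whether a single methoxy group would have the same effect remains open. So does whether an unsubstituted phenyl or an aminophenyl would stand with compounds 1 and 2 or with compound 3.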